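The compounds below may be only part of what the source reports. "The series", "measured", "known", "first", "only" and "open" are said of these compounds alone.

Of the compounds shown here, three have numbers so far in a functional assay on HepG2 cells (Homo sapiens) for inhibition, read by sulforhodamine B assay, with a stated time of 3 days; on this read-out lower numbers stand for stronger inhibition and higher numbers for weaker inhibition. Compound 1 (`O=C1Nc2ccccc2/C1=C\C(=O)c1c[nH]c2ccccc12`) gives 2110 nM, compound 2 (`O=C1Nc2ccc(F)cc2/C1=C\C(=O)c1cnc2ccc(Cl)nn12`) gives 3090 nM, and compound 3 (`COc1ccc(C(=O)Nc2ccc3c(c2)/C(=C/Nc2cccc(N4CCN(C)CC4)c2)C(=O)N3)cc1`) gives 1780 nM. Compound 3 stands within the scatter of both other compounds, so the three numbers do not separate, although the structures are clearly different. Going by the values given here, no two measured compounds differ in only one place, so the series offers no measured step from which to scale a single change.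

Compound 4 (`CN1CCN(c2cccc(N/C=C3\C(=O)Nc4ccc(NC(=O)c5c(F)cccc5F)cc43)c2)CC1`) is the next to be read in this assay. Relative to compound 3, it carries 2,6-difluorophenyl in place of 4-methoxyphenyl on a carbonyl carbon. The rest of the structure is unchanged.

No step beyond the scatter is expected, and neither direction is favoured. This expectation rests on compound 3 at 1780 nM and on the fact that compound 1 at 2110 nM and compound 2 at 3090 nM both lie within the scatter of it, which is thin evidence for a single change. The expected step is small, a 1.0-fold higher number from compound 3 to compound 4 (0.00 log units; within the scatter). For compound 4 the estimated value is 1800 nM, with an expected range from 700 nM to 4500 nM.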

Compound 4, half-maximal inhibitory concentration: 3030 nM
For compound 4 the middle estimate is 1.7-fold (0.23 log units) below the measured one, within the range that was stated.
By their numbers in this assay, from the lowest: compounds 3, 1, 4 and 2 (each within the scatter of the next).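

In this assay, going by these compounds alone, the exchange of 4-methoxyphenyl for 2,6-difluorophenyl on a carbonyl carbon gives a 1.7-fold higher number from compound 3 to compound 4 (0.23 log units; within the scatter) and is the first single-place step that can be read. At this place, then, two groups with the same count of heavy atoms and one aromatic carbon ring each, one with a hydrogen-bond acceptor and one with none, do not separate on this read-out, so neither the methoxy group nor the two fluorines can be said to matter here. No measurement is at hand that would tie the size of this step to any property of either group.

As far as these compounds go, both groups on this carbonyl carbon are substituted phenyl rings, so it remains open whether a carboxylic acid, an aliphatic amine or a longer alkyl chain in the same place would give a step beyond the scatter. From the compounds shown here alone, the rest of compound 3 also remains open, as this single pair gives no reading of any change elsewhere in the structure, such as replacing the methylpiperazine with a morpholine.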